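Swapping 2-chlorophenyl for 4-nitrophenyl on a shared core

The source may report more compounds than this note shows. Statements on the series, on what has been measured and on what is new or still open speak of the compounds shown alone.

In a functional assay on A549 cells (Homo sapiens) for antiproliferative activity, read by MTT assay, with a stated time of 48 h (on this read-out higher numbers stand for weaker inhibition and lower numbers for stronger inhibition), compound 1 `O=C(/C=C/c1ccc(O)c(O)c1)N1CCN(c2ccccc2Cl)CC1` gives 1.44 ug/mL. Compound 2 `COc1ccccc1N1CCN(C(=O)/C=C/c2ccc(O)c(O)c2)CC1` gives 0.98 ug/mL, and compound 3 `O=C(/C=C/c1ccc(O)c(O)c1)N1CCN(c2cccc(C(F)(F)F)c2)CC1` gives 1.74 ug/mL. Compound 1 therefore lies within the usual scatter of both. Compound 4 `O=C(/C=C/c1ccc(O)c(O)c1)N1CCN(c2ccc([N+](=O)[O-])cc2)CC1` has 4-nitrophenyl in place of 2-chlorophenyl on an amine nitrogen in a ring. For the measured compounds named here, one measured step bears on this change, with methoxy in place of chloro on an aromatic carbon. It is small: a 1.5-fold lower number from compound 1 to compound 2 (0.17 log units; within the scatter). Going by the values given here, no measured compound carries 4-nitrophenyl, so this is only a loose guide. The expected step is a 1.0-fold lower number from compound 1 to compound 4 (0.01 log units; within the scatter), which means no change beyond the scatter is anticipated. For compound 4 the estimated value is 1.4 ug/mL, with an expected range of 0.7 ug/mL to 2.8 ug/mL.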

Compound 4, half-maximal inhibitory concentration: 1.56 ug/mL
Beside the measured number, compound 4's estimate is 1.1-fold (0.05 log units) below it; the range from low to high includes it.
By their numbers in this assay, from the lowest: compounds 2, 1, 4 and 3 (each within the scatter of the next).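

In this assay, placing 4-nitrophenyl on the amine nitrogen in the ring gives a 1.1-fold higher number from compound 1 to compound 4 (0.03 log units; within the scatter) as the step from the chlorinated compound, and a 1.6-fold higher number from compound 2 to compound 4 (0.20 log units; within the scatter) as the step from the methoxy compound. Both steps stay within the scatter, so the nitro-bearing ring, the largest of these three groups by heavy atoms, cannot be told apart from 2-chlorophenyl or 2-methoxyphenyl here. No supporting measurement explains this result.

On these data alone, whether this position tolerates groups without an aromatic ring remains open. A plain alkyl chain or a carboxylic acid there could still move the number beyond the scatter.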